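Methyl in Place of Methylsulfonyl on a Ring Nitrogen

A few compounds are considered here, and "the series" means these few. Any claim that something is new, unique, unknown or untested is made for them only; others in the source may bear on it.

compound 1 `Cc1nc(N2CCN(S(C)(=O)=O)CC2)nc2ccc(NC(=O)COc3ccc(Cl)cc3)cc12` — > 10000 nM
compound 2 `Cc1nc(N2CCC(N3CCCC3)CC2)nc2ccc(NC(=O)C(C)Oc3ccc(Cl)cc3)cc12` — 258 nM
compound 3 `Cc1nc(N2CCN(C3CCOCC3)CC2)nc2ccc(NC(=O)COc3ccc(OC(F)(F)F)cc3)cc12` — 7 nM

Three compounds sharing one core were tested in an assay on CHO-K1 cells for displacement of a labelled ligand from melanin-concentrating hormone receptor 1 (Homo sapiens), with a stated time of 2 h; a lower number here means a stronger inhibitor, a higher number a weaker inhibitor. For compound 1 the value > 10000 nM is a limit of the assay and not a number (the limit of > 10000 nM in this assay, at which 1 of the 3 values shown sits), so compound 1 stands at the weak end of what is shown. Compound 2 gives 258 nM and compound 3 gives 7 nM, both well inside the measurable range. Compound 4 `Cc1nc(N2CCN(C)CC2)nc2ccc(NC(=O)COc3ccc(Cl)cc3)cc12` differs from compound 1 in one place: methyl in place of methylsulfonyl on an amine nitrogen in a ring. Within the data shown here, no measured pair shows this change, so its size is not known from the data. Still, the expected step is a large one toward stronger inhibition, an at least 100-fold lower number from compound 1 to compound 4 (2.00 log units; beyond the scatter), and compound 4 is estimated at 100 nM, with a range from 10 nM to 1500 nM.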

Compound 4, half-maximal inhibitory concentration: 220 nM
For compound 4 the middle estimate is 2.2-fold (0.34 log units) below the measured one, and the stated range covers the measured number.
By their numbers in this assay, from the lowest: compound 3; then compounds 4 and 2 (each within the scatter of the next). At a limit, above all of these: compound 1.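

In this assay, putting methyl in place of methylsulfonyl on the ring nitrogen gives an at least 45-fold lower number from compound 1 to compound 4 (1.65 log units; beyond the scatter), the first single change that can be read among these compounds. It shows that the group on this nitrogen can decide whether inhibition is measurable at all. The full size of the step stays unread, as compound 1 is held at a limit of the assay: the limit of > 10000 nM in this assay, at which 1 of the 4 values shown sits.

Still open, from the compounds shown here alone, is whether other groups on this nitrogen, such as acetyl, ethyl or a bare hydrogen, behave like methyl or like methylsulfonyl. Also open, going by these compounds, is whether the step holds with trifluoromethoxy in place of chloro.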